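Methyl in place of hydrogen on the oxygen: compound 3

A few compounds are considered here, and "the series" means these few. Any claim that something is new, unique, unknown or untested is made for them only; others in the source may bear on it.

Of the compounds shown here, two have a number so far. Compound 1 `Cc1cccc(/C(CCN2CCN(c3ccccn3)CC2)=N/O)c1` gives 74% in a functional assay on HEK293 cells with D(4) dopamine receptor (Homo sapiens) as the target, read by FLIPR; a higher number here means a larger maximal response, a lower number a smaller maximal response. Compound 2 `Cc1cc(C)cc(/C(CCN2CCN(c3ccccn3)CC2)=N/O)c1` gives 55% in this assay. Among the measured compounds shown here, compound 2 thus stands lowest of the two numbers measured, and its nearest neighbour is compound 1; the single step in hand, methyl in place of hydrogen on an aromatic carbon, reads a number 19 percentage points lower from compound 1 to compound 2 (beyond the scatter).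

Compound 3 `CO/N=C(\CCN1CCN(c2ccccn2)CC1)c1cc(C)cc(C)c1` is the next member to be measured in this assay. It differs from compound 2 as follows: methyl in place of hydrogen on an oxygen. For the measured compounds named here, the change sits on the oxygen, not on the aromatic carbon, so the step of a number 19 percentage points lower from compound 1 to compound 2 (beyond the scatter) does not bear on it, and no measured pair shows the effect of a methyl on this oxygen. With nothing to ground a direction, the working assumption is a step that stays within the usual scatter, and the estimated step is no change at the digits printed from compound 2 to compound 3 (within the scatter). Compound 3 is therefore expected to give 55% in this assay, with an expected range from 35% to 75%, the width reflecting the absence of any comparable step.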

Compound 3, largest response reached (reported as efficacy), in percent of the reference or control that the assay uses: 71%
Compound 3: middle estimate off by 16 percentage points, on the low side, and the stated range covers the measured number.
By their numbers in this assay, from the lowest: compound 2; then compounds 3 and 1 (each within the scatter of the next).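

In this assay, hydroxy to methoxy on the oxygen whose other neighbour is the double-bonded nitrogen gives a number 16 percentage points higher from compound 2 to compound 3 (beyond the scatter) on the core of compound 2, which makes this oxygen a place where the maximal response moves and shows that the hydrogen on it is not needed for compound 3 to give 71% in this series. The direction is opposite to a number 19 percentage points lower from compound 1 to compound 2 (beyond the scatter) so the same exchange of methyl for hydrogen does not move the number the same way at the two places, although each direction rests on a single pair. Nothing available bears on why the number moves at the oxygen.

From the compounds shown here alone, it remains open whether the rise on going from hydroxy to methoxy also holds on the core of compound 1, which carries one methyl fewer on the aromatic ring. Also open, going by these compounds, is how far the response follows the group on this oxygen when methyl gives way to ethyl, to a longer chain, to benzyl or to a chain ending in a carboxylic acid.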